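The source may report more compounds than this note shows. Statements on the series, on what has been measured and on what is new or still open speak of the compounds shown alone.

Measured in a functional assay on A549 cells (Homo sapiens) for cytotoxicity, read by MTT assay; a higher number here means a weaker inhibitor, a lower number a stronger inhibitor:
Compound 1 `CCn1cc(C(=O)Nc2ccccc2O)c(=O)c2cc(F)c(N3CCNC(C)C3)c(F)c21`: 24800 nM
Compound 2 `CCn1cc(C(=O)Nc2ccc(Cl)cn2)c(=O)c2cc(F)c(N3CCNC(C)C3)c(F)c21`: 3300 nM
Compound 3 `CCn1cc(C(=O)Nc2cc([N+](=O)[O-])ccc2F)c(=O)c2cc(F)c(N3CCNC(C)C3)c(F)c21`: 1700 nM

Compound 3, at 1700 nM, cannot be told apart from compound 2, since a 1.9-fold lower number from compound 2 to compound 3 (0.29 log units; within the scatter). Compound 1 stands clearly apart from it, as a 15-fold lower number from compound 1 to compound 3 (1.16 log units; beyond the scatter).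

Compound 4 `CCn1cc(C(=O)NCc2ccc(OC)cc2)c(=O)c2cc(F)c(N3CCNC(C)C3)c(F)c21` keeps the shared core and has 4-methoxybenzyl in place of 2-fluoro-5-nitrophenyl on an amide-type nitrogen. Among the compounds with values here, all the measured steps change the group at this same place. Besides the step to compound 3, a 7.5-fold lower number from compound 1 to compound 2 (0.88 log units; beyond the scatter). These steps show that the group on this nitrogen can shift the number in this assay by a modest to large amount. None of the three measured compounds carries a benzyl group, however, so they give no direct guide to the direction.

Compound 3 lies at the low end of the measured span, and the high end is held by compound 1 at 24800 nM, so a move upward seems the more likely outcome. The expected change is a modest rise, estimated as a 3.5-fold higher number from compound 3 to compound 4 (0.55 log units; beyond the scatter). For compound 4 the estimated value is 6000 nM, with an expected range from 1800 nM to 20000 nM.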

Compound 4, half-maximal inhibitory concentration: 7000 nM
Compound 4: the middle estimate sits 1.2-fold (0.07 log units) below what was measured; low and high end bracket the measured number.
By their numbers in this assay, from the lowest: compounds 3 and 2 (each within the scatter of the next); then compound 4; then compound 1.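

In this assay, within the data shown here, 4-methoxybenzyl is the first benzyl group seen on this amide-type nitrogen, and it does not fall outside the span set by the three earlier groups: the change gives a 4.1-fold higher number from compound 3 to compound 4 (0.61 log units; beyond the scatter) and a 2.1-fold higher number from compound 2 to compound 4 (0.33 log units; beyond the scatter), yet also a 3.5-fold lower number from compound 1 to compound 4 (0.55 log units; beyond the scatter). The number therefore rises relative to the 2-fluoro-5-nitrophenyl and 5-chloropyridin-2-yl compounds but stays lower than that of the 2-hydroxyphenyl compound, so a benzyl group at this place gives an intermediate result among these four compounds, not an extreme one. Nothing available explains this order.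

The change from 2-fluoro-5-nitrophenyl to 4-methoxybenzyl alters both the link to the nitrogen and the groups on the ring, so the compounds shown cannot say which of these accounts for the rise. A plain benzyl or a 4-methoxyphenyl group on this nitrogen would separate the two, and a longer chain such as 2-phenylethyl would show whether the number keeps rising as the ring moves further out.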